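The source may report more compounds than this note shows. Statements on the series, on what has been measured and on what is new or still open speak of the compounds shown alone.

Values in an assay on isolated protein for inhibition of malate dehydrogenase, mitochondrial (Sus scrofa), with stated times of 45 min and 30 min (a higher number here means a weaker inhibitor, a lower number a stronger inhibitor), for the measured members of the series:

compound 1, `O=S(=O)(Nc1ccc2oc(-c3ccccc3)nc2c1)c1cccc(C(F)(F)F)c1`: > 63000 nM, a limit of the assay
compound 2, `O=S(=O)(Nc1ccc(-c2nc3ccccc3o2)cc1)c1cccc(Cl)c1`: > 63000 nM, a limit of the assay
compound 3, `COc1cccc(S(=O)(=O)Nc2ccc3oc(-c4ccccc4)nc3c2)c1`: > 63000 nM, a limit of the assay

Compound 3 therefore stands nowhere in particular on the numbers: its value in this assay is a limit, and the limit of > 63000 nM in this assay, at which 3 of the 3 values shown sit, holds for every value shown, so none of the three compounds can be ordered against the others. Among the measured compounds shown here, the one step that joins two measured compounds, a step that the two limits leave unreadable from compound 1 to compound 3, is a methoxy in place of a trifluoromethyl on an aromatic carbon, and its size is not readable between two limits.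

The next compound is compound 4, `O=S(=O)(Nc1ccc2oc(-c3ccccc3)nc2c1)c1ccccc1Cl`. It differs from compound 3 in one place: 2-chlorophenyl in place of 3-methoxyphenyl on a sulfonyl sulfur. For the measured compounds named here, no measured step bears on this change in a readable way, since the only measured step is unreadable and every value is a limit. The expectation for compound 4 in this assay is that it remains at the limit, with no step beyond the scatter discernible; the step that the limit leaves unreadable from compound 3 to compound 4 is an estimate only, not readable against a limit. Compound 4 is expected at about 100000 nM, within 30000 nM to 400000 nM.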

Compound 4, half-maximal inhibitory concentration: > 63000 nM
Compound 4 ended at the assay's limit (the forecaster's own chance of this, stated with the estimate: 85%); the middle value does not contradict the limit.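

No step can be read from compound 3 to compound 4 in this assay, because both values are limits of the assay, and the same holds for every compound in the series: the limit of > 63000 nM in this assay, at which 4 of the 4 values shown sit.

The compounds shown leave open whether any of them differs from another in this assay, and which change to the shared core or its aryl groups would bring a value inside the measurable range.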